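The compounds below may be only part of what the source reports. "The series", "measured", "known", "first", "only" and "open" are said of these compounds alone.

Measured so far in a functional assay on MCF7 cells (Homo sapiens) for antiproliferative activity; a lower number here means a stronger inhibitor, a higher number a weaker inhibitor:
- compound 1 `CCN(C)CCCOc1ccc2cc(NC(=O)c3ccc(O)c(CC=C(C)C)c3)c(=O)oc2c1C` gives 2190 nM in this assay
- compound 2 `CC(C)=CCc1cc(C(=O)Nc2cc3ccc(OCCCNC(C)C)c(C)c3oc2=O)ccc1O` gives 740 nM in this assay

Compound 2 holds the lower of the two numbers. Compound 3 `CC(C)=CCc1cc(C(=O)Nc2cc3ccc(OCCCN(C)C(C)(C)C)c(C)c3oc2=O)ccc1O` differs from it by one change (methyl(tert-butyl)amino in place of isopropylamino on a saturated chain carbon, three bonds along the chain from an oxygen on an aromatic ring). Among the measured compounds shown here, the one measured step at this place, a 3.0-fold lower number from compound 1 to compound 2 (0.47 log units; beyond the scatter), brought in isopropylamino for ethyl(methyl)amino. Compound 3 gives isopropylamino up again, so a step of similar size towards a higher number is expected in this assay here. The expected step is a 2.7-fold higher number from compound 2 to compound 3 (0.43 log units; beyond the scatter) by this estimate. Compound 3 is estimated at 2000 nM (range 700 nM to 6000 nM).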

Compound 3, half-maximal inhibitory concentration: 1140 nM
Estimate against measurement, compound 3: 1.8-fold (0.24 log units) above; the measured number falls inside the stated range.
By their numbers in this assay, from the lowest: compounds 2, 3 and 1 (each within the scatter of the next, the first and the last beyond it).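

In this assay, the bulkier methyl(tert-butyl)amino, with no hydrogen-bond donor, replaces isopropylamino, which has one, without a clear shift (a 1.5-fold higher number from compound 2 to compound 3 (0.19 log units; within the scatter)). Tert-butyl in place of ethyl on the amine nitrogen likewise gives no clear shift (a 1.9-fold lower number from compound 1 to compound 3 (0.28 log units; within the scatter)), so compound 3 cannot be separated from either compound 2 or compound 1, although those two stand apart. Nothing available explains these numbers.

Going by these compounds, whether tert-butylamino, without the methyl, would behave like compound 2 or compound 3 remains open. So does whether a piperidine, a morpholine or a longer chain would move the number beyond the scatter.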